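Methyl to ethyl on the amide-type ring nitrogen

The source may hold more compounds than are shown below. What is called first, only, known or untested is meant among the compounds shown, and "the series" means these compounds.

Compound 1 `CN1CCN(c2ccc(Nc3ncc4c(n3)N(C3CCCC3)CC(=O)N4C)cc2)CC1` gives 3290 nM in a functional assay on HCT-116 cells (Homo sapiens) for inhibition, read by MTT assay, with a stated time of 48 h; a lower number here means a stronger inhibitor, a higher number a weaker inhibitor. Compound 3 `CCN1C(=O)CN(C2CCCC2)c2nc(Nc3ccc(N4CCN(C)CC4)cc3)ncc21` carries methyl in place of hydrogen on a saturated chain carbon bound to an amide-type nitrogen in a ring relative to compound 1 and in this assay compound 3 gives 7960 nM. The step is a 2.4-fold higher number from compound 1 to compound 3 (0.38 log units; beyond the scatter). Compound 2 `CN1CCN(c2ccc(Nc3ncc4c(n3)N(C3CCCC3)CC(=O)N4C)nc2)CC1` gives 9730 nM in this assay; the difference between the core of compound 2 and the core of compound 1 is not broken down here. The values of compound 2 and compound 3 lie within the scatter of each other, while compound 2 sits a clear step above compound 1.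

Compound 4 `CCN1C(=O)CN(C2CCCC2)c2nc(Nc3ccc(N4CCN(C)CC4)cn3)ncc21` has not yet been measured in this assay. It differs from compound 2 by methyl in place of hydrogen on a saturated chain carbon bound to an amide-type nitrogen in a ring, the place being the same, word for word, as in the pair compound 1 to compound 3, so this is the same change made on the core of compound 2. Because that change gave a 2.4-fold higher number from compound 1 to compound 3 (0.38 log units; beyond the scatter) and compound 2 stands at 9730 nM, compound 4 is expected to give about 22000 nM in this assay. The expected step is a 2.3-fold higher number from compound 2 to compound 4 (0.35 log units; beyond the scatter). The likely range for compound 4 is estimated as 9000 nM to 55000 nM, on a single precedent only.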

Compound 4, half-maximal inhibitory concentration: 16400 nM
Compound 4: the middle estimate sits 1.3-fold (0.13 log units) above what was measured; the measured number falls inside the stated range.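

On the core of compound 2, the methyl to ethyl change gives a 1.7-fold higher number from compound 2 to compound 4 (0.23 log units; within the scatter) in this assay, a step that taken alone cannot be told apart from repeat scatter. Set beside the earlier pair, the step on the second core does not differ from the first beyond what two such steps allow: the same change on two cores in this assay, a 2.4-fold higher number (0.38 log units; beyond the scatter) from compound 1 to compound 3 and a 1.7-fold higher number (0.23 log units; within the scatter) from compound 2 to compound 4, 1.4-fold (0.16 log units) apart, within the scatter of two such steps This shows that, on these two cores, the change carries over with no detectable difference between the steps, though only the step on the core of compound 1 lies beyond the scatter; it does not show that the change would carry to any other core, and two pairs give no account of why the numbers move as they do.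

Still open, from the compounds shown here alone, is how a longer chain such as propyl, or a branched one such as isopropyl, would read in the same place on either core. Equally open, going by these compounds, is whether a chain ending in an amine or a carboxylic acid would read any differently from ethyl there.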